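The source may hold more compounds than are shown below. What is called first, only, known or untested is meant among the compounds shown, and "the series" means these compounds.

Of the compounds shown here, two of one series have been measured in an assay on isolated protein for displacement of a labelled ligand from Apoptosis regulator Bcl-2 (Homo sapiens), read by fluorescence polarization; on this read-out higher numbers stand for weaker inhibition and lower numbers for stronger inhibition. Compound 1 `CN(C)CC[C@H](CSc1ccccc1)Nc1ccc(S(=O)(=O)NC(=O)c2ccc(N3CCC(=Cc4ccc(F)cc4)CC3)cc2)cc1[N+](=O)[O-]` gives 3.4 nM in this assay. Going by the values given here, compound 2 `CN(C)CC[C@H](CSc1ccccc1)Nc1ccc(S(=O)(=O)NC(=O)c2ccc(N3CCC(=Cc4ccccc4Cl)CC3)cc2)cc1[N+](=O)[O-]` gives 0.7 nM in this assay, the lowest of the two numbers, and the only measured step, a 4.9-fold lower number from compound 1 to compound 2 (0.69 log units; beyond the scatter), is a modest one that lies beyond the scatter. Compound 3 `CN(C)CC[C@H](CSc1ccccc1)Nc1ccc(S(=O)(=O)NC(=O)c2ccc(N3CCC(=Cc4ccccc4C(F)(F)F)CC3)cc2)cc1[N+](=O)[O-]` has not yet been measured. It differs from compound 2 by trifluoromethyl in place of chloro on an aromatic carbon. Among the compounds with values here, no measured step bears directly on this change: the single known step, a 4.9-fold lower number from compound 1 to compound 2 (0.69 log units; beyond the scatter), exchanged one substituted phenyl for a differently substituted one, whereas here the phenyl is kept and only the substituent changes from chloro to trifluoromethyl. With nothing closer to lean on, compound 3 is expected to stay near compound 2. The step of a 1.4-fold higher number from compound 2 to compound 3 (0.15 log units; within the scatter) is estimated to fall within the scatter rather than beyond it, in either direction. For compound 3 the expected value in this assay is 1 nM, with a range from 0.3 nM to 3.5 nM.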

Compound 3, inhibition constant: 2 nM
Compound 3: the middle estimate sits 2.0-fold (0.30 log units) below what was measured, within the range that was stated.
By their numbers in this assay, from the lowest: compound 2; then compounds 3 and 1 (each within the scatter of the next).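

In this assay, the aromatic carbon ortho to a large group proves sensitive to which group it carries: a 2.9-fold higher number from compound 2 to compound 3 (0.46 log units; beyond the scatter) is a modest change, but it lies beyond the scatter. The earlier step could not show this, since it changed both the substituent and its place on the phenyl at once, whereas here only the substituent differs. The second step, a 1.7-fold lower number from compound 1 to compound 3 (0.23 log units; within the scatter), lies within the scatter, so 2-(trifluoromethyl)phenyl and 4-fluorophenyl cannot be told apart in this assay, and a group at this place does not in itself bring the lower number seen for compound 2; the compounds shown come with no measurement that would explain the difference between chloro and trifluoromethyl.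

The compounds shown leave open whether another group on the same aromatic carbon, such as bromo, methyl or methoxy, would match chloro or fall nearer trifluoromethyl. They also leave open whether chloro would give a similar number elsewhere on the phenyl, since the only other placed substituent is a different group, fluoro.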